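The compounds below may be only part of what the source reports. "The series", "measured", "known", "first", "only" and "open" are said of these compounds alone.

Compound 1 `CCOC(=O)/C=C/[C@H](CC(C)C)NC(=O)[C@H](CC(C)C)NC(=O)[C@H](CC(C)C)NC(=O)C1=CCCN(C(=O)OC(C)(C)C)C1` gives > 6 h in an ADME assay for metabolic stability, in the presence of a further agent that is not named here (on this read-out higher numbers stand for a longer-lived compound and lower numbers for a shorter-lived compound), which is a limit of the assay and not a number.
Compound 2 `CCOC(=O)/C=C/[C@H](CC(C)C)NC(=O)[C@H](CC(C)C)NC(=O)[C@H](CC(C)C)NC(=O)c1cccc(O)c1C` gives > 6 h in this assay, again a limit of the assay.
Compound 3 `CCOC(=O)/C=C/[C@H](CC(C)C)NC(=O)[C@H](CO)NC(=O)[C@@H](NC(=O)OCc1ccccc1)C(C)C` gives > 6 h in this assay, also a limit of the assay.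

Compound 3 therefore stands exactly where the other two stand: the limit of > 6 h in this assay, at which 3 of the 3 values shown sit. For the measured compounds named here, because none of the three compounds reports a number, no step between measured compounds can be worked out, and nothing shows how far past the limit any of them reaches. The three share the ethyl ester chain and the amide backbone, and they differ in the group attached at the end of that backbone, yet all three read the same in this assay.

Compound 4 `CCOC(=O)/C=C/[C@H](CC(C)C)NC(=O)[C@H](CO)NC(=O)[C@@H](NC(=O)c1cccc(O)c1C)C(C)C` has not been measured. It differs from compound 3 in one place: 3-hydroxy-2-methylphenyl in place of benzyloxy on a carbonyl carbon. Compound 2 carries this same group on its carbonyl carbon and also reaches the limit of the assay.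

On these grounds the change from compound 3 to compound 4 is expected to give no step beyond the scatter, the expected step being a step that the limit leaves unreadable from compound 3 to compound 4. Compound 4 is therefore estimated at 8 h, within 4 h to 20 h, and most likely will again be reported only as a limit rather than a number.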

Compound 4, half-life: > 6 h
Compound 4 was reported as a limit; the forecaster's own chance of this, stated with the estimate: 80%; the middle value lies beyond the limit too.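

Because compound 3 and compound 4 both report only a limit in this assay and not a number, no step can be read between them: the limit of > 6 h in this assay, at which 4 of the 4 values shown sit. Going by these compounds, how long any of the four compounds actually lasts stays open, and so does whether 3-hydroxy-2-methylphenyl in place of benzyloxy on a carbonyl carbon changes the half-life at all.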